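The compounds below may be only part of what the source reports. "The series", "measured", "known", "first", "only" and "open" are said of these compounds alone.

Compound 1 `COc1cc2nccc(Oc3ccc(Nc4nn(C)cc4C(=O)NCc4ccccc4)cc3)c2cc1C(N)=O`: > 10000 nM
Compound 2 `COc1cc2nccc(Oc3ccc(Nc4nn(C)cc4C(=O)NC4CCCCCCC4)cc3)c2cc1C(N)=O`: 3210 nM

In a functional assay on BaF3 cells (Mus musculus) for antiproliferative activity, read by CCK-8 assay and cell counting, with a stated time of 76 h (a higher number here means a weaker inhibitor, a lower number a stronger inhibitor), compound 1 gives > 10000 nM, which is a limit of the assay and not a number. It therefore serves as a weak and open-ended starting point.

Compound 3 `COc1cc2nccc(Oc3ccc(Nc4nn(C)cc4C(=O)Nc4ccc(F)cc4)cc3)c2cc1C(N)=O` keeps the core of compound 1 and carries 4-fluorophenyl in place of benzyl on an amide-type nitrogen. Among the measured compounds shown here, no compound with 4-fluorophenyl on this nitrogen has been measured yet.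

For the measured compounds named here, only one measured step bears on the change. It replaces the same benzyl on the same nitrogen, with cyclooctyl as the new group: an at least 3.1-fold lower number from compound 1 to compound 2 (0.49 log units; beyond the scatter). This shows that the number in this assay can respond to the group at this place, but the entering group there is a different one. Going by an at least 3.1-fold lower number from compound 1 to compound 2 (0.49 log units; beyond the scatter), a modest move to a lower number is expected, and a result that again reaches the limit of the assay would be no surprise.

The expected change is an at least 2.0-fold lower number from compound 1 to compound 3 (0.30 log units; that floor lies within the scatter). For compound 3 the estimated value is 5000 nM, with an expected range from 1200 nM to 15000 nM.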

Compound 3, half-maximal inhibitory concentration: 3060 nM
Compound 3: the middle estimate sits 1.6-fold (0.21 log units) above what was measured, and the stated range covers the measured number.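

Putting 4-fluorophenyl in place of benzyl on the amide-type nitrogen gives an at least 3.2-fold lower number from compound 1 to compound 3 (0.51 log units; beyond the scatter) in this assay, so a second replacement at this place also lowers the number, and the effect is not confined to cyclooctyl. Between the two replacements there is a 1.0-fold lower number from compound 2 to compound 3 (0.02 log units; within the scatter), which means that cyclooctyl and 4-fluorophenyl cannot be told apart in this assay, although only 4-fluorophenyl is an aromatic ring. Compound 1 stands at a limit and not at a number, so each step from it gives only a floor: the limit of > 10000 nM in this assay, at which 1 of the 3 values shown sits.

From the compounds shown here alone, what remains open is how much of the step from benzyl belongs to the fluorine and how much to the loss of the carbon linking the ring of benzyl to the nitrogen, a question that a plain phenyl or a 4-fluorobenzyl group on this nitrogen would help to separate. Going by these compounds, it is also open whether a group carrying an amine or a carboxylic acid at this place would take the number further than cyclooctyl and 4-fluorophenyl do.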